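A few compounds are considered here, and "the series" means these few. Any claim that something is new, unique, unknown or untested is made for them only; others in the source may bear on it.

Measured so far:
- compound 1, `Cc1cc(Nc2cc(-c3ccccc3)[nH]n2)n2nc(SCc3ccc(Cl)cc3)nc2n1`: 31800 nM
- compound 2, `Cc1cc(Nc2cc(-c3ccccc3)[nH]n2)n2nc(SCCc3ccccc3)nc2n1`: 37400 nM

Within the data shown here, in an ADME assay on GES1 cells (Homo sapiens) for inhibition, read by MTT assay, with a stated time of 72 h (on this read-out lower numbers stand for stronger inhibition and higher numbers for weaker inhibition), compound 2 gives 37400 nM, the highest of the two numbers; the nearest is compound 1, and the only step in the set, a 1.2-fold higher number from compound 1 to compound 2 (0.07 log units; within the scatter), stays within the scatter. Compound 3, `Cc1cc(Nc2cc(-c3ccccc3)[nH]n2)n2nc(SCC3CC3)nc2n1`, differs from compound 2 by cyclopropyl in place of benzyl on a saturated chain carbon bound to a sulfur. Among the measured compounds shown here, the one measured step, from compound 1 to compound 2, alters the same saturated chain carbon bound to a sulfur, and it moved the number only slightly; it is the only guide here, and it gives no sign that a change at this place shifts the read-out beyond the scatter. A step of about a 1.1-fold higher number from compound 2 to compound 3 (0.03 log units; within the scatter) is therefore expected, that is, none that can be told from the scatter. For compound 3 the estimate in this assay is 40000 nM, in the range 18000 nM to 90000 nM.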

Compound 3, half-maximal inhibitory concentration: > 50000 nM
Compound 3: no number, only a limit; the forecaster's own chance of this, stated with the estimate: 20%; middle value at least 1.2-fold (0.09 log units) from the limit.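

In this assay, compound 3 gives only a limit, > 50000 nM, and not a number. With cyclopropyl at this saturated chain carbon bound to a sulfur, the series shows an at least 1.3-fold higher number from compound 2 to compound 3 (0.12 log units; that floor lies within the scatter) and an at least 1.5-fold higher number from compound 1 to compound 3 (0.19 log units; that floor lies within the scatter); both floors lie within the scatter, so the true size of neither step can be read. What is new is that a three-membered non-aromatic ring of carbon at this place, with the smaller group counted at 3 heavy atoms, takes the read-out to the edge of its measurable range: the limit of > 50000 nM in this assay, at which 1 of the 3 values shown sits.

On these data alone, how far compound 3 lies past that limit remains unknown, as does whether any change at this place moves the number beyond the scatter. As far as these compounds go, the effect of an amine, a carboxylic acid or a longer chain at this place also stays open.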